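Compound 2 to compound 3: dimethylamino replaced by 4-methylpiperazin-1-yl

A few compounds are considered here, and "the series" means these few. Any claim that something is new, unique, unknown or untested is made for them only; others in the source may bear on it.

Of the compounds shown here, two on the shared core have been read so far in an ADME assay on Vero cells (Chlorocebus sabaeus) for cytotoxicity, read by neutral red uptake, with a stated time of 48 h; on this read-out lower numbers stand for stronger inhibition and higher numbers for weaker inhibition. Compound 2 `CN(C)c1nc(Cl)nc2c1ncn2CCCNc1ccnc2cc(Cl)ccc12` reads > 11400 nM, which is a limit of the assay and not a number. Among the measured compounds shown here, compound 1 `Clc1ccc2c(NCCn3cnc4c(N5CCN(c6ccccc6)CC5)nc(Cl)nc43)ccnc2c1` gives 4040 nM, the only true number in the set.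

Compound 3 `CN1CCN(c2nc(Cl)nc3c2ncn3CCCNc2ccnc3cc(Cl)ccc23)CC1` keeps the core and chain of compound 2 and changes one place: 4-methylpiperazin-1-yl stands in place of dimethylamino on an aromatic carbon (4-methylpiperazin-1-yl in place of dimethylamino on an aromatic carbon). For the measured compounds named here, no single-place step between measured compounds is available to size this change.

The nearest guide is compound 1 at 4040 nM, which also carries a six-membered non-aromatic ring on the core but differs from compound 3 in more than one place. On that weak basis, a modest move toward stronger inhibition in this assay is expected, estimated as an at least 1.4-fold lower number from compound 2 to compound 3 (0.15 log units; that floor lies within the scatter). A second limit reading would not be a surprise. For compound 3 the estimated value is 8000 nM, with an expected range of 3000 nM to 20000 nM.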

Compound 3, half-maximal inhibitory concentration: > 10100 nM
Compound 3: only a limit was reported; the forecaster's own chance of this, stated with the estimate: 35%; middle value at least 1.2-fold (0.10 log units) away from the limit.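

In this assay compound 3 gives > 10100 nM, a limit of the assay and not a number. Among the compounds shown here, compound 2 gives > 11400 nM, likewise a limit, so no step between compound 2 and compound 3 can be read. Still open, on these data alone, is whether 4-methylpiperazin-1-yl in place of dimethylamino changes the read-out at all.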